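The source may hold more compounds than are shown below. What is called first, only, known or untested is meant among the compounds shown, and "the series" means these compounds.

Measured compounds:
Compound 1, `CNCC[C@@H]1CCO[C@H](c2ccccc2)O1`: in an assay for displacement of a labelled ligand from Sigma non-opioid intracellular receptor 1 (Cavia porcellus), read by scintillation counting (on this read-out lower numbers stand for stronger inhibition and higher numbers for weaker inhibition), compound 1 gives 449 nM.
Compound 2, `NCC[C@@H]1CCOC(c2ccccc2)(c2ccccc2)O1`: in this assay compound 2 gives > 10000 nM, which is a limit of the assay and not a number.

Compound 2 thus stands at the limit of > 10000 nM in this assay, at which 1 of the 2 values shown sits, and no number is known for it; of the two values shown, only compound 1 is a measured figure. The piece now follows the step from compound 2 to compound 3, `c1ccc(CNCC[C@@H]2CCOC(c3ccccc3)(c3ccccc3)O2)cc1`, which has not yet been tested in this assay. The change is benzyl in place of hydrogen on an amine nitrogen, with the rest of compound 2 kept as it is. No comparable step between measured compounds is shown, so the size of the step can only be estimated. The step from compound 2 to compound 3 is expected to move the value towards stronger inhibition, and by more than the usual scatter, as an at least 12-fold lower number from compound 2 to compound 3 (1.09 log units; beyond the scatter). For compound 3 in this assay the expected value is 800 nM, within a range from 100 nM to 8000 nM.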

Compound 3, inhibition constant: 320 nM
Compound 3: middle estimate off by 2.5-fold (0.40 log units), on the high side; measured number inside the range.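

Compound 3 shows that this amine nitrogen, on the core of compound 2, is a place where a single change registers strongly in this assay: benzyl in place of hydrogen gives an at least 31-fold lower number from compound 2 to compound 3 (1.49 log units; beyond the scatter). That step is a large one, yet it marks only the smallest size the change can have, as compound 2 carries a limit of the assay and not a number: the limit of > 10000 nM in this assay, at which 1 of the 3 values shown sits. Compound 3 also gives this core its first measured figure, with compound 3 at 320 nM, so later changes at this nitrogen have a number to be read against.

The compounds shown leave open whether it is the aromatic ring of the benzyl group that matters or simply the presence of a carbon substituent on the nitrogen, which a methyl, a phenethyl or a longer alkyl chain at the same place would separate. On these data alone, compound 1 differs from compound 3 in more than one place, so how the rest of the core bears on the value also remains open.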